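Removing the bromine from a kinase inhibitor core

A few compounds are considered here, and "the series" means these few. Any claim that something is new, unique, unknown or untested is made for them only; others in the source may bear on it.

Of the compounds shown here, two with one shared core have been measured in an assay for inhibition of Rho-associated protein kinase 1 (Homo sapiens), read by TR-FRET, with stated times of 5 min and 2 h; on this read-out lower numbers stand for stronger inhibition and higher numbers for weaker inhibition. Compound 1 `CCc1n[nH]cc1-c1cc2c(s1)C(=O)NC(C)(C)N2C` gives 350 nM, whereas compound 2 `CN1c2c(sc(-c3cn[nH]c3)c2Br)C(=O)NC1(C)C` gives 22 nM; compound 2 stands lowest of the two numbers, and its gap to compound 1 lies beyond the usual scatter, so compound 2 is the stronger inhibitor of the pair. Compound 3 `CN1c2cc(-c3cn[nH]c3)sc2C(=O)NC1(C)C` is compound 2 with a single change: hydrogen in place of bromo on an aromatic carbon of a five-membered aromatic ring with 1 sulfur, next to the ring atom that bears a 1H-pyrazol-4-yl group. Among the measured compounds shown here, no measured pair shows this exact step, and compound 1 differs from compound 2 in more than this one place, so the higher number of compound 1 350 nM only hints at the direction. The step is expected to cost some potency, with a 3.2-fold higher number from compound 2 to compound 3 (0.50 log units; beyond the scatter) pointing toward a higher number. Compound 3 is therefore estimated at 70 nM, within a range from 25 nM to 250 nM.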

Compound 3, half-maximal inhibitory concentration: 130 nM
Beside the measured number, compound 3's estimate is 1.9-fold (0.27 log units) below it; the measured number falls inside the stated range.
By their numbers in this assay, from the lowest: compound 2; then compound 3; then compound 1.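

In this assay, the bromo group on the aromatic carbon next to the ring atom that bears a 1H-pyrazol-4-yl group now has a measured worth: hydrogen in its place gives a 5.9-fold higher number from compound 2 to compound 3 (0.77 log units; beyond the scatter), an effect that compound 1 could not isolate because it differs from compound 2 in more than one place. The second difference can also be read on its own, as taking away the ethyl group gives a 2.7-fold lower number from compound 1 to compound 3 (0.43 log units; beyond the scatter), so the two single changes each lower the number in the direction of bromo present and ethyl absent. Nothing available explains why either change shifts the number.

On these data alone, whether chloro, methyl or a nitrile on that same carbon would match bromo remains open. The compounds shown also cannot tell whether the ethyl step keeps its size when bromo is present.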